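The compounds below may be only part of what the source reports. "The series", "measured", "known", "first", "only" and "open" are said of these compounds alone.

Compound 3 `Cc1ccc(CSc2cc(Cl)c(C)cc2S(=O)(=O)/N=C(\N)n2nccc2-c2ccccc2)cc1` gives 14000 nM in a functional assay on HCT-116 cells (Homo sapiens) for cytotoxicity, read by MTT assay, with a stated time of 72 h (a higher number here means a weaker inhibitor, a lower number a stronger inhibitor), level with compound 2 `Cc1cc(S(=O)(=O)/N=C(\N)n2nccc2-c2ccccc2)c(SCc2ccc(C(F)(F)F)cc2)cc1Cl`, which gives 14000 nM, and close to compound 1 `Cc1cc(S(=O)(=O)/N=C(\N)n2nccc2-c2ccccc2)c(SCc2ccccc2)cc1Cl`, which gives 12000 nM; all three values sit within the scatter of one another. Compound 4 `Cc1cc(S(=O)(=O)/N=C(\N)n2nccc2-c2ccccc2)c(SCc2ccccc2C(F)(F)F)cc1Cl` differs from compound 3 by 2-(trifluoromethyl)phenyl in place of 4-methylphenyl on a saturated chain carbon bound to a sulfur. The measured steps that bear on this are the benzyl variations already seen: a 1.2-fold higher number from compound 1 to compound 2 (0.07 log units; within the scatter), a 1.2-fold higher number from compound 1 to compound 3 (0.07 log units; within the scatter) and no change at the digits printed from compound 2 to compound 3 (within the scatter), none of which moves beyond the scatter. For the measured compounds named here, the 2-(trifluoromethyl)phenyl group itself appears in no measured compound, so nothing beyond those steps can be drawn on. The expectation is therefore a step of no size beyond the scatter, no change at the digits printed from compound 3 to compound 4 (within the scatter). Compound 4 is estimated at 14000 nM, with a range from 7000 nM to 28000 nM.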

Compound 4, half-maximal inhibitory concentration: 16000 nM
Compound 4: middle estimate off by 1.1-fold (0.06 log units), on the low side, within the range that was stated.
By their numbers in this assay, from the lowest: compounds 1, 2, 3 and 4 (each within the scatter of the next).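

In this assay, the 2-(trifluoromethyl)benzyl group stays within the scatter of each benzyl group met so far, with a 1.1-fold higher number from compound 3 to compound 4 (0.06 log units; within the scatter) against 4-methylphenyl and a 1.1-fold higher number from compound 2 to compound 4 (0.06 log units; within the scatter) against 4-(trifluoromethyl)phenyl and a 1.3-fold higher number from compound 1 to compound 4 (0.12 log units; within the scatter) against plain phenyl. Moving trifluoromethyl from the 4-(trifluoromethyl)phenyl form to the 2-(trifluoromethyl)phenyl form therefore separates nothing here, and all four compounds read as one group. No supporting measurement bears on why these values coincide. From the compounds shown here alone, what an amine or a carboxylic acid on that phenyl ring, or a longer chain in place of the benzyl, would do in this assay stays open.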